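Moving the Fluoro on the Sulfonamide Aryl Group

The source may hold more compounds than are shown below. What is called first, only, known or untested is meant among the compounds shown, and "the series" means these compounds.

compound 1 `CCOC(=O)C1=CCCCC1S(=O)(=O)Nc1ccc(Cl)cc1F` gives 160 nM
compound 2 `CCOC(=O)C1=CCCCC1S(=O)(=O)Nc1ccccc1` gives 260 nM
compound 3 `CCOC(=O)C1=CCCCC1S(=O)(=O)Nc1ccccc1F` gives 75 nM

In a functional assay on RAW264.7 cells (Mus musculus) for inhibition (on this read-out higher numbers stand for weaker inhibition and lower numbers for stronger inhibition), compound 3 has the lowest of the three numbers, 75 nM on this read-out, and its gaps to both other compounds lie beyond the scatter. Compound 4 `CCOC(=O)C1=CCCCC1S(=O)(=O)Nc1cccc(F)c1` has not yet been measured. It carries 3-fluorophenyl in place of 2-fluorophenyl on a sulfonamide nitrogen and so holds the same atoms, joined differently.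

Among the compounds with values here, two measured steps bear on this change. Fluoro in place of hydrogen gave a 3.5-fold lower number from compound 2 to compound 3 (0.54 log units; beyond the scatter) (modest), and hydrogen in place of chloro gave a 2.1-fold lower number from compound 1 to compound 3 (0.33 log units; beyond the scatter) (also modest). Neither step shifts a fluoro to another place on the ring, so the data offer no direct measure of this change. Part of the gain seen with compound 3 may be lost, and a modest rise is expected, with compound 2 at 260 nM as a rough upper guide. The expected change is a 1.7-fold higher number from compound 3 to compound 4 (0.24 log units; within the scatter) in this assay by this estimate. The estimate for compound 4 is 130 nM (expected range 55 nM to 300 nM).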

Compound 4, half-maximal inhibitory concentration: 150 nM
Estimate against measurement, compound 4: 1.2-fold (0.06 log units) below, within the range that was stated.
By their numbers in this assay, from the lowest: compounds 3, 4, 1 and 2 (each within the scatter of the next, the first and the last beyond it).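

In this assay, the shift from 2-fluorophenyl to 3-fluorophenyl gives a 2.0-fold higher number from compound 3 to compound 4 (0.30 log units; within the scatter), so the two placements of the fluoro on the sulfonamide nitrogen's aryl group cannot be told apart. Fluoro in place of hydrogen now gives a 1.7-fold lower number from compound 2 to compound 4 (0.24 log units; within the scatter), whereas the same exchange with 2-fluorophenyl gave a 3.5-fold lower number from compound 2 to compound 3 (0.54 log units; beyond the scatter), so 3-fluorophenyl is separated neither from the unsubstituted phenyl nor from 2-fluorophenyl, and only the latter stands clear of the unsubstituted phenyl. Nothing available explains this result.

The compounds shown leave open whether a methoxy group, an amine or a carboxylic acid in place of the fluoro of 3-fluorophenyl would move the number beyond the scatter. They also leave open whether the small difference between the two fluoro placements would hold up on repeated measurement.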